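Working notes on compounds 1 to 4, cytotoxicity

The source may hold more compounds than are shown below. What is called first, only, known or untested is meant among the compounds shown, and "the series" means these compounds.

Measured so far:
Compound 1, `O=C(Cn1c(-c2ccccc2)cc(-c2ccccc2)c1-c1ccco1)Nc1nc2ccccc2s1`. In an ADME assay on HEK-293T cells (Homo sapiens) for cytotoxicity, read by MTT assay, with a stated time of 72 h (on this read-out higher numbers stand for weaker inhibition and lower numbers for stronger inhibition), compound 1 gives < 50000 nM, which is a limit of the assay.
Compound 2, `O=C(Cn1c(-c2ccccc2)cc(-c2ccco2)c1-c1ccco1)Nc1nc2ccccc2s1`. Compound 2 gives < 50000 nM, again a limit.
Compound 3, `CCc1nnc(NC(=O)Cn2c(-c3ccccc3)cc(-c3ccco3)c2-c2ccco2)s1`. Compound 3 gives < 50000 nM, also a limit.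

Compound 2 therefore stands at a limit only, with no number of its own, and the two further values shown are limits as well, all sitting at the limit of < 50000 nM in this assay, at which 3 of the 3 values shown sit. Two one-point changes connect the measured compounds: a step that the two limits leave unreadable from compound 1 to compound 2 and a step that the two limits leave unreadable from compound 2 to compound 3. Neither step can be read, because the limit of < 50000 nM in this assay, at which 3 of the 3 values shown sit, is where every value involved sits.

Compound 4, `O=C(Cn1c(-c2ccccc2)cc(-c2cccc3ccccc23)c1-c1ccco1)Nc1nc2ccccc2s1`, differs from compound 2 in one place: naphthalen-1-yl in place of furan-2-yl on an aromatic carbon. Of the measured steps, none bears readably on this change, and their sizes are not known. No step beyond the scatter can be expected or ruled out from what is shown; the likeliest outcome is another limit.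

The value of compound 4 is estimated at 20000 nM, with a range from 4000 nM to 50000 nM. For compound 4 the step this estimate means is expected to be a step that the limit leaves unreadable from compound 2 to compound 4.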

Compound 4, half-maximal inhibitory concentration: < 50000 nM
Compound 4: a limit, no number (the forecaster's own chance of this, stated with the estimate: 70%); the middle value is on the limit's open side.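

In this assay compound 4 gives < 50000 nM, again a limit. No step from compound 2 to compound 4 or from compound 1 to compound 4 can be read, because both ends of each pair sit at the same limit: the limit of < 50000 nM in this assay, at which 4 of the 4 values shown sit.

The compounds shown leave open how far any of the four lies from that limit, and whether any change on the shared core alters cytotoxicity at all.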